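The compounds below may be only part of what the source reports. "The series", "measured", "known", "first", "only" and "open" are said of these compounds alone.

Measured in a functional assay on WiDr cells (Homo sapiens) for antiproliferative activity, read by sulforhodamine B assay, with a stated time of 48 h; a lower number here means a stronger inhibitor of growth, a higher number a weaker inhibitor of growth:
- compound 1, `Cc1ccc(S(=O)(=O)N2CC[C@@H](Cl)C[C@@H]2CC(C)C)cc1`, gives 22000 nM
- compound 2, `CCCCCCC[C@H]1C[C@H](Cl)CCN1S(=O)(=O)c1ccc(C)cc1`, gives 54000 nM
- compound 3, `Cc1ccc(S(=O)(=O)N2CC[C@@H](Cl)C[C@@H]2c2ccccc2)cc1`, gives 37000 nM

Compound 2 shows the highest number of the three in this assay. The step of a 1.5-fold lower number from compound 2 to compound 3 (0.16 log units; within the scatter) stays within the scatter, whereas a 2.5-fold higher number from compound 1 to compound 2 (0.39 log units; beyond the scatter) lies beyond it, so only the gap to compound 1 counts as a real difference. Compound 4, `CCCCCCC[C@H]1C[C@H](Br)CCN1S(=O)(=O)c1ccc(C)cc1`, differs from compound 2 in one place: bromo in place of chloro on a saturated ring carbon. Within the data shown here, none of the measured steps touches this spot. The steps of a 2.5-fold higher number from compound 1 to compound 2 (0.39 log units; beyond the scatter), a 1.7-fold higher number from compound 1 to compound 3 (0.23 log units; within the scatter) and a 1.5-fold lower number from compound 2 to compound 3 (0.16 log units; within the scatter) all exchange the group on the other ring carbon, and only the first of them reaches beyond the scatter. Among the measured compounds shown here, nothing among the measured compounds bears directly on the exchange of chloro for bromo, so no step beyond the scatter is expected in this assay from compound 2 to compound 4. Compound 4 is therefore estimated at 54000 nM, with a range from 25000 nM to 120000 nM. The expected step is no change at the digits printed from compound 2 to compound 4 (within the scatter).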

Compound 4, concentration for 50% growth inhibition: > 100000 nM
Compound 4: a limit, no number; the forecaster's own chance of this, stated with the estimate: 10%; middle value at least 1.8-fold (0.26 log units) away from the limit.
By their numbers in this assay, from the lowest: compounds 1, 3 and 2 (each within the scatter of the next, the first and the last beyond it). At a limit, above all of these: compound 4.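

Among these compounds, every earlier step changed the group on the other ring carbon, so this is the first reading of a change on the ring carbon three ring bonds from the ring nitrogen. In this assay compound 4 gives > 100000 nM, a limit of the assay and not a number: the limit of > 100000 nM in this assay, at which 1 of the 4 values shown sits. Bromo in place of chloro gives an at least 1.8-fold higher number from compound 2 to compound 4 (0.26 log units; that floor lies within the scatter), so this exchange brings no lower number, but its floor alone does not establish a real loss of growth inhibition, and the true size of the step remains unknown.

The compounds shown leave open how fluoro, iodo or an amine would read on this ring carbon. They also leave open whether bromo in place of chloro would act the same way with the isobutyl of compound 1 or the phenyl of compound 3 on the other ring carbon.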